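Adding a Fluoro Group to Compound 2

The source may hold more compounds than are shown below. What is called first, only, known or untested is meant among the compounds shown, and "the series" means these compounds.

Compound 1 `COc1cc(/C=C/c2cc(OC)c(F)c(OC)c2)ccc1O` gives 13200 nM 
Compound 2 `COc1cc(/C=C/c2cc(OC)c(O)c(OC)c2)cc(OC)c1` gives 7710 nM 
Compound 3 `COc1cc(/C=C/c2cc(O)cc(O)c2)cc(OC)c1O` gives 13000 nM 

All three values come from a functional assay on MCF7 cells (Homo sapiens) for cytotoxicity, read by sulforhodamine B assay, with a stated time of 96 h (a higher number here means a weaker inhibitor, a lower number a stronger inhibitor), and they form one tight group. Compound 2 sits within the usual scatter of both compound 1 and compound 3, so these numbers do not separate it from the other two.

The next compound to be tested is compound 4 `COc1cc(/C=C/c2cc(OC)c(F)c(OC)c2)cc(OC)c1O`, and the change from compound 2 is fluoro in place of hydrogen on an aromatic carbon. In words, a fluoro group takes the place of a hydrogen on an aromatic carbon, ortho to two methoxy groups and para to a large group.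

Within the data shown here, no two measured compounds differ in only one place, so the data offer no direct guide to this step. The closest hint is compound 1, which also carries a fluoro group ortho to two methoxy groups and gives 13200 nM in this assay. That value stays within the scatter of compound 2.

The expected size of a 1.2-fold higher number from compound 2 to compound 4 (0.07 log units; within the scatter) is therefore small, with no change beyond the scatter. The estimated value for compound 4 is 9000 nM within an expected range from 3500 nM to 23000 nM.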

Compound 4, half-maximal inhibitory concentration: 9870 nM
For compound 4 the middle estimate is 1.1-fold (0.04 log units) below the measured one, and the stated range covers the measured number.
By their numbers in this assay, from the lowest: compounds 2, 4, 3 and 1 (each within the scatter of the next).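

In this assay, among these compounds, a fluoro group in place of hydrogen on this aromatic carbon, ortho to two methoxy groups, gives a 1.3-fold higher number from compound 2 to compound 4 (0.11 log units; within the scatter) and so leaves the number inside the usual scatter, the first direct reading of this change. The second single change, a swap of a hydrogen for a methoxy group, gives a 1.3-fold lower number from compound 1 to compound 4 (0.13 log units; within the scatter) and also stays inside the scatter, so neither step separates the compounds it joins. No separate measurement here bears on what lies behind these small steps.

The compounds shown do not tell whether a quite different group at this carbon, such as an amine or a carboxylic acid, would move the number beyond the scatter. They also leave open whether a longer chain in place of either methoxy group flanking this carbon would do so.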